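The compounds below may be only part of what the source reports. "The series", "measured", "known", "first", "only" and "open" are said of these compounds alone.

Series notes. Compound 3 `Cc1ccc2[nH]c(=O)c(/C=N/CCO)cc2c1` carries a methyl on its core; compound 1 `O=c1[nH]c2ccccc2cc1/C=N/CCO` has the same core with hydrogen in that place. In a functional assay, read by spectrophotometry, with a stated time of 3 min (a higher number here means a weaker inhibitor, a lower number a stronger inhibitor), compound 3 gives 1190000 nM, and compound 1 gives 1210000 nM. The step of a 1.0-fold higher number from compound 3 to compound 1 (0.01 log units; within the scatter) corresponds to the change (hydrogen in place of methyl on an aromatic carbon). Compound 2 `Cc1ccc2[nH]c(=O)c(/C=N/c3ccc(S(N)(=O)=O)cc3)cc2c1` keeps the methyl on the core but differs from compound 3 in the remainder of the molecule; in this assay compound 2 gives 1200000 nM. The difference between the core of compound 2 and that of compound 3 is not broken down here, and the values of compound 1, compound 2 and compound 3 all lie within the scatter of one another. Compound 4 `NS(=O)(=O)c1ccc(/N=C/c2cc3ccccc3[nH]c2=O)cc1` has not yet been measured. It relates to compound 2 as compound 1 relates to compound 3: hydrogen in place of methyl on an aromatic carbon, the same change at the same place. In this assay the expected step is no change at the digits printed from compound 2 to compound 4 (within the scatter), beside the measured 1.0-fold higher number from compound 3 to compound 1 (0.01 log units; within the scatter), an expectation that rests on the step of a 1.0-fold higher number from compound 3 to compound 1 (0.01 log units; within the scatter) lying within the scatter. For compound 4 the estimated value in this assay is 1200000 nM, with a likely range from 600000 nM to 2400000 nM.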

Compound 4, half-maximal inhibitory concentration: 1610000 nM
Compound 4: the middle estimate sits 1.3-fold (0.13 log units) below what was measured; measured number inside the range.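

In this assay, hydrogen in place of methyl on an aromatic carbon gives a 1.3-fold higher number from compound 2 to compound 4 (0.13 log units; within the scatter). Set beside the earlier step, the change carries from one core to the other with no difference that can be told apart: the same change on two cores in this assay, a 1.0-fold higher number (0.01 log units; within the scatter) from compound 3 to compound 1 and a 1.3-fold higher number (0.13 log units; within the scatter) from compound 2 to compound 4, 1.3-fold (0.12 log units) apart, within the scatter of two such steps

Going by these compounds alone, this shows that, on these two cores, exchanging the methyl for hydrogen leaves each step within the scatter, but it does not show that the change has no effect at all, since a small real effect would be hidden in that scatter, and with no sizeable step to carry over, the comparison is only a weak test of transfer. Still open, going by these compounds, is whether a larger group at the same place, such as a methoxy, a chlorine or a trifluoromethyl, would behave alike on both cores. Also open, on these data alone, is whether the step would hold with an amine, a carboxylic acid or a longer chain in the remainder of the molecule.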